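A few compounds are considered here, and "the series" means these few. Any claim that something is new, unique, unknown or untested is made for them only; others in the source may bear on it.

Measured compounds: compound 1 `CS(=O)(=O)c1ccc2c(Cc3cccc(C(=O)O)n3)c(-c3ccccc3)nn2c1` with 5400 nM in a functional assay on cells for antagonist activity at prostaglandin E2 receptor EP1 subtype (Rattus norvegicus), read by fluorescence and calcium flux, with a stated time of 60 s; a lower number here means a stronger inhibitor, a higher number a weaker inhibitor; compound 2 `COc1ccc(-c2nn3cc(Cl)ccc3c2Cc2cccc(C(=O)O)n2)cc1` with 5400 nM in this assay.

Compound 2 stands level with compound 1 at the digits shown; the two values lie within the scatter of each other. Compound 3 `O=C(O)c1cccc(Cc2c(C3CCCCC3)nn3cc(Cl)ccc23)n1` differs from compound 2 in one place: cyclohexyl in place of 4-methoxyphenyl on an aromatic carbon. No step of this kind is shown among the measured compounds, so the direction is open. A modest step toward weaker inhibition is expected for compound 3, a 1.5-fold higher number from compound 2 to compound 3 (0.17 log units; within the scatter), with a wide range. Compound 3 is estimated at 8000 nM in this assay, between 2500 nM and 25000 nM.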

Compound 3, half-maximal inhibitory concentration: 1200 nM
Compound 3: middle estimate off by 6.7-fold (0.82 log units), on the high side, outside the stated range (below it).
By their numbers in this assay, from the lowest: compound 3; then compounds 1 and 2 (each within the scatter of the next).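

In this assay, cyclohexyl in place of 4-methoxyphenyl on this aromatic carbon gives a 4.5-fold lower number from compound 2 to compound 3 (0.65 log units; beyond the scatter) and is the first step beyond the scatter among the compounds shown. This position therefore responds to the group it carries, and an aromatic ring is not required there for inhibition at this level. Nothing measured here accounts for the change.

On these data alone, it remains open whether the loss of the aromatic ring or of the methoxy group matters more, which phenyl on the same core would help to separate. As far as these compounds go, whether cyclopentyl or tert-butyl would serve as well is also open.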